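Aryl for alkenyl on the amide-bearing chain carbon

The source may hold more compounds than are shown below. What is called first, only, known or untested is meant among the compounds shown, and "the series" means these compounds.

Measured compounds: compound 1 `C/C=C/[C@@H](CC(=O)O)NC(=O)[C@@H]1CCCN1S(=O)(=O)c1cc(Cl)cc(Cl)c1` gives 13 nM; compound 2 `O=C(O)C[C@@H](NC(=O)[C@@H]1CCN1S(=O)(=O)c1cc(Cl)cc(Cl)c1)c1ccc(Br)cc1` gives 2.1 nM.

In an assay on RPMI-8866 cells for inhibition of integrin alpha-4/beta-1 (Homo sapiens) (on this read-out higher numbers stand for weaker inhibition and lower numbers for stronger inhibition), compound 1 holds the higher of the two numbers, and compound 2 sits well apart from it. Compound 3 `O=C(O)C[C@@H](NC(=O)[C@@H]1CCCN1S(=O)(=O)c1cc(Cl)cc(Cl)c1)c1ccc(OC(F)(F)F)cc1` differs from compound 1 by 4-(trifluoromethoxy)phenyl in place of prop-1-en-1-yl on a saturated chain carbon bound to an amide-type nitrogen and a saturated chain carbon. For the measured compounds named here, no measured pair shows this exact change, so the size of the step is open; an aryl-bearing compound 2 gives 2.1 nM, so a move toward stronger inhibition is expected. The step of a 3.3-fold lower number from compound 1 to compound 3 (0.51 log units; beyond the scatter) is the estimated outcome. Compound 3 is expected at 4 nM, in the range 1.5 nM to 12 nM.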

Compound 3, half-maximal inhibitory concentration: 2.6 nM
Compound 3: the middle estimate sits 1.5-fold (0.19 log units) above what was measured; the measured number falls inside the stated range.
By their numbers in this assay, from the lowest: compounds 2 and 3 (each within the scatter of the next); then compound 1.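

In this assay, putting 4-(trifluoromethoxy)phenyl in place of prop-1-en-1-yl on this saturated chain carbon gives a 5.0-fold lower number from compound 1 to compound 3 (0.70 log units; beyond the scatter) with the rest of the molecule unchanged. For the compounds shown here, this is the first clean reading at this position, and it shows that the carbon accepts a much larger aromatic group with stronger inhibition. Compound 2 also carries an aryl group, but it differs from compound 1 in a second place and could not isolate this change.

Left open is what a plain phenyl or a 4-aminophenyl group would give here, and so whether the ring or its trifluoromethoxy group carries the step. Nothing shown gives a reason for the step.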